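The source may hold more compounds than are shown below. What is called first, only, known or untested is meant among the compounds shown, and "the series" means these compounds.

The measured compounds are these:

Compound 1 `O=C1Nc2ccc(Br)cc2/C1=N/NC(=S)N/N=C/c1ccc(-c2ccccc2)cc1` in a functional assay on HeLa cells (Homo sapiens) for inhibition, read by MTT assay (on this read-out lower numbers stand for stronger inhibition and higher numbers for weaker inhibition), gives 3250 nM.
Compound 2 `O=C1Nc2ccc(Br)cc2/C1=N/NC(=S)N/N=C/c1ccccc1Br` in this assay gives > 50000 nM, which is a limit of the assay and not a number.
Compound 3 `Cc1ccc2c(c1)/C(=N/NC(=S)N/N=C/c1ccccc1Br)C(=O)N2` in this assay gives > 50000 nM, again a limit of the assay.

Compound 1 holds the only number shown; the other two values are limits. The cores of compound 1 and compound 2 differ, but that difference is not broken down here. From compound 2 to compound 3 the change is methyl in place of bromo on an aromatic carbon, and the step it made is a step that the two limits leave unreadable from compound 2 to compound 3. The same change, word for word in its place, is made from compound 1 to compound 4 `Cc1ccc2c(c1)/C(=N/NC(=S)N/N=C/c1ccc(-c3ccccc3)cc1)C(=O)N2`, namely (methyl in place of bromo on an aromatic carbon). Because of the limit of > 50000 nM in this assay, at which 2 of the 3 values shown sit, the size of that step cannot be read from the measured pair. The expectation for compound 4 therefore rests on compound 1 alone, at 3250 nM, with a step of about a 1.2-fold higher number from compound 1 to compound 4 (0.09 log units; within the scatter) expected, set within the usual scatter. Compound 4 is thus estimated at 4000 nM, expected to lie between 1500 nM and 12000 nM.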

Compound 4, half-maximal inhibitory concentration: > 50000 nM
Compound 4 gave a limit, no number; the forecaster's own chance of this, stated with the estimate: 8%; middle value at least 12-fold (1.09 log units) from the limit.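

In this assay, putting methyl in place of bromo on the core of compound 1 gave an at least 15-fold higher number from compound 1 to compound 4 (1.18 log units; beyond the scatter), a large step towards weaker inhibition that lies beyond the scatter. The value of compound 4, > 50000 nM, is a limit of the assay and not a number. The change therefore matters on this core, but the series does not show whether it behaves alike on the core of compound 2, as the step from compound 2 to compound 3 and any comparison of the two steps cannot be read: the limit of > 50000 nM in this assay, at which 3 of the 4 values shown sit.

The compounds shown leave open whether chloro, fluoro or an amine in place of the bromo of compound 1 would give a number in this assay or a limit. They also leave open what a carboxylic acid or a longer chain would do at that same aromatic carbon.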